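Methoxy for Methyl on a Scaffold Without Cytotoxicity

The source may report more compounds than this note shows. Statements on the series, on what has been measured and on what is new or still open speak of the compounds shown alone.

Three compounds sharing one core were tested in an ADME assay on NIH3T3 cells (Mus musculus) for cytotoxicity, read by XTT assay, with a stated time of 24 h; on this read-out lower numbers stand for stronger inhibition and higher numbers for weaker inhibition. Compound 1 `Fc1ccc(C2CC(c3ccc(Cl)s3)=NN2c2nc(-c3ccc(C(F)(F)F)cc3)cs2)cc1` carries a trifluoromethyl group on its outer phenyl ring. In this assay compound 1 reaches only the limit of the assay, > 500 ug/mL, and no number. Compound 2 `O=[N+]([O-])c1ccc(-c2csc(N3N=C(c4ccc(Cl)s4)CC3c3ccc(F)cc3)n2)cc1` bears nitro in place of trifluoromethyl on an aromatic carbon. In this assay compound 2 likewise returns only a limit, > 500 ug/mL. Compound 3 `Cc1ccc(-c2csc(N3N=C(c4ccc(Cl)s4)CC3c3ccc(F)cc3)n2)cc1` has methyl in place of trifluoromethyl on an aromatic carbon. In this assay compound 3 also stops at the limit, > 500 ug/mL. The three steps between them, a step that the two limits leave unreadable from compound 1 to compound 2, a step that the two limits leave unreadable from compound 1 to compound 3 and a step that the two limits leave unreadable from compound 2 to compound 3, cannot be sized because of the limit of > 500 ug/mL in this assay, at which 3 of the 3 values shown sit. Compound 3 thus stands at the same limit as the other two, and nothing in the numbers sets it apart.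

Compound 4 `COc1ccc(-c2csc(N3N=C(c4ccc(Cl)s4)CC3c3ccc(F)cc3)n2)cc1` differs from compound 3 by methoxy in place of methyl on an aromatic carbon. Within the data shown here, no measured step speaks to this particular change, and the steps among the measured compounds give no readable size in this assay. With every neighbour sitting at the limit, compound 4 is expected to sit there as well, so the expected step is a step that the limit leaves unreadable from compound 3 to compound 4. Compound 4 is estimated at 600 ug/mL, with a range from 300 ug/mL to 2000 ug/mL.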

Compound 4, half-maximal inhibitory concentration: 103 ug/mL
Beside the measured number, compound 4's estimate is 5.8-fold (0.77 log units) above it; the whole stated range lies above it.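

In this assay, the group on the aromatic carbon para to a large group turns out to matter: methoxy in place of methyl gives an at least 4.8-fold lower number from compound 3 to compound 4 (0.68 log units; beyond the scatter). Methoxy also separates from the other two groups at this place, with an at least 4.8-fold lower number from compound 2 to compound 4 (0.68 log units; beyond the scatter) and an at least 4.8-fold lower number from compound 1 to compound 4 (0.68 log units; beyond the scatter), so the shared core does not stay at the limit whatever is placed there, as the earlier compounds alone might have suggested. The steps among compound 1, compound 2 and compound 3 still cannot be read, because those three values are limits and not numbers: the limit of > 500 ug/mL in this assay, at which 3 of the 4 values shown sit.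

On these data alone, each of the three new steps has a limit at one end, so they give only a smallest size, and how far methoxy really lies from methyl, nitro or trifluoromethyl stays unknown. The compounds shown also leave open whether the drop belongs to methoxy alone or would also appear with an ethoxy, a hydroxyl or an amine at this place, and whether methoxy elsewhere on the same ring would give it.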